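Cyclopropyl epimer in the amide series

The source may hold more compounds than are shown below. What is called first, only, known or untested is meant among the compounds shown, and "the series" means these compounds.

Notes on the amide series on a shared core. Compound 1 `CC(=O)N1CC2CC(C1)N2` gives 150 nM in an assay on SH-EP1 cells for displacement of a labelled ligand from Neuronal acetylcholine receptor; alpha4/beta2 (Homo sapiens), read by scintillation counting; on this read-out higher numbers stand for weaker inhibition and lower numbers for stronger inhibition. Compound 2 `O=C(C1CCC1)N1CC2CC(C1)N2` gives 16 nM in this assay, and compound 3 `O=C([C@@H]1C[C@@H]1F)N1CC2CC(C1)N2` gives 1.7 nM in this assay. Compound 3 stands lowest of the three numbers: an 88-fold lower number from compound 1 to compound 3 (1.95 log units; beyond the scatter) and a 9.4-fold lower number from compound 2 to compound 3 (0.97 log units; beyond the scatter), both beyond the scatter, alongside a 9.4-fold lower number from compound 1 to compound 2 (0.97 log units; beyond the scatter).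

Compound 4 `O=C([C@H]1C[C@@H]1F)N1CC2CC(C1)N2` differs from compound 3 only in that (the two compounds have the same atoms and bonds; at least one stereo element is drawn with a configuration in one of them and without one in the other: 1 of 4 stereo elements differ; a stereocentre at a saturated ring carbon is drawn S in compound 3 and R in compound 4). For the measured compounds named here, none of the measured steps concerns a stereocentre; all three exchange the group on the carbonyl carbon, and those steps ran from modest to large. Going by the values given here, they set no direction for this step. The measured numbers show only that the 2-fluorocyclopropyl amide stands far below the methyl and cyclobutyl amides. Compound 4 is therefore expected to remain toward the low end, with a step of a 2.4-fold higher number from compound 3 to compound 4 (0.37 log units; beyond the scatter) that is estimated slightly upward and could fall on either side. Compound 4 is estimated at 4 nM, with a range from 1 nM to 20 nM.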

Compound 4, inhibition constant: 5.4 nM
Estimate against measurement, compound 4: 1.4-fold (0.13 log units) below; the range from low to high includes it.
By their numbers in this assay, from the lowest: compound 3; then compound 4; then compound 2; then compound 1.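

For the compounds shown here, compound 3 and compound 4 have the same atoms and bonds, so this is the first step to show that configuration at a saturated ring carbon of the 2-fluorocyclopropyl amide matters on its own in this assay: a 3.2-fold higher number from compound 3 to compound 4 (0.50 log units; beyond the scatter). The standing of this amide below the others does not depend on the S drawing, though the R drawing holds less of the gain, with a 3.0-fold lower number from compound 2 to compound 4 (0.47 log units; beyond the scatter) and a 28-fold lower number from compound 1 to compound 4 (1.44 log units; beyond the scatter). The stereo step carries one reservation on how the pair is drawn: the fact that one of compounds 3 and 4 is drawn with a defined configuration and the other without, at the place where they differ

On these data alone, how much of this standing belongs to the fluorine stays open, and an unsubstituted cyclopropyl amide would settle that. As far as these compounds go, the other configurations of the 2-fluorocyclopropyl group also remain open.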